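The source may report more compounds than this note shows. Statements on the series, on what has been measured and on what is new or still open speak of the compounds shown alone.

Among the compounds with values here, compound 3 `COc1cc2c(cc1N1CCNCC1)N(S(=O)(=O)c1ccc(-c3ccccn3)s1)CC2` is the simplest of the three measured members. Within the data shown here, in a functional assay with growth hormone secretagogue receptor type 1 (Homo sapiens) as the target (on this read-out lower numbers stand for smaller maximal responses and higher numbers for larger maximal responses), compound 3 gives 0.8, the lowest of the three values, though a number 0.10 lower from compound 1 to compound 3 (within the scatter), so only the step to compound 2 separates it clearly. Compound 1 `COc1cc2c(cc1N1C[C@@H](C)N[C@@H](C)C1)N(S(=O)(=O)c1ccc(-c3ccccn3)s1)CC2` carries a 3,5-dimethylpiperazin-1-yl group where compound 3 has an unsubstituted piperazin-1-yl; in this assay compound 1 gives 0.9. Compound 2 `COc1cc2c(cc1N1CCN[C@H](C)C1)N(S(=O)(=O)c1ccc(-c3ccccn3)s1)CC2` keeps a single methyl on the saturated ring; in this assay compound 2 gives 1, and a number 0.20 lower from compound 2 to compound 3 (beyond the scatter), while a number 0.10 higher from compound 1 to compound 2 (within the scatter).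

Compound 4 `COc1cc2c(cc1N1C[C@H](C)NC(C)(C)C1)N(S(=O)(=O)c1ccc(-c3ccccn3)s1)CC2` has not yet been measured. It differs from compound 3 in one place: a group of 9 heavy atoms (7 carbon, 2 nitrogen; one six-membered non-aromatic ring with 2 hetero atoms) in place of a group of 6 heavy atoms (4 carbon, 2 nitrogen; one six-membered non-aromatic ring with 2 hetero atoms), on an aromatic carbon. Among the measured compounds shown here, the steps that bear on this are the methylations of the saturated ring, namely a number 0.10 lower from compound 1 to compound 3 (within the scatter) and a number 0.20 lower from compound 2 to compound 3 (beyond the scatter); adding methyls moved the intrinsic activity only modestly, and in either direction. Compound 4 is therefore expected to sit close to the other three, with a number 0.10 higher from compound 3 to compound 4 (within the scatter) expected as the step from its parent. The estimate for compound 4 is 0.9, expected to fall between 0.75 and 1.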

Compound 4, intrinsic activity: the largest response reached, as a fraction of the reference agonist's: 1
Estimate against measurement, compound 4: 0.10 below; the measured number falls inside the stated range.
By their numbers in this assay, from the lowest: compounds 3, 1, 2 and 4 (each within the scatter of the next, the first and the last beyond it).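

Placing the group of 9 heavy atoms on the aromatic carbon ortho to a methoxy group, in place of piperazin-1-yl, gives a number 0.20 higher from compound 3 to compound 4 (beyond the scatter) in this assay, so this position accepts a more heavily substituted saturated ring than those in the earlier compounds while keeping a full-sized response. Within the data shown here, the larger group is not separated from the smaller methylated rings, with no change at the digits printed from compound 2 to compound 4 (within the scatter) and a number 0.10 higher from compound 1 to compound 4 (within the scatter), so adding to the ring beyond the single methyl of compound 2 brings no distinguishable gain, and the unsubstituted ring of compound 3 stands apart from compound 2 and compound 4 but not from compound 1. No measurement at hand accounts for why the substituted rings behave in this way.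

The compounds shown leave open whether the response survives a methyl on the ring nitrogen, or the replacement of the piperazine by morpholine or by an open-chain amine such as a 2-aminoethylamino group. They also leave open how the opposite arrangement of the ring methyls would read, since each stereocentre appears here in one form only.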